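A few compounds are considered here, and "the series" means these few. Any claim that something is new, unique, unknown or untested is made for them only; others in the source may bear on it.

Compound 1 `Cc1ccc(S(=O)(=O)Oc2ccc3c(c2)C(=O)C=CC3=O)cc1`: 16400 nM
Compound 2 `C=CCOc1ccc2c(c1)C(=O)C=CC2=O`: 10200 nM

In a functional assay on KB cells (Homo sapiens) for cytotoxicity (on this read-out higher numbers stand for weaker inhibition and lower numbers for stronger inhibition), compound 2 gives 10200 nM and compound 1 gives 16400 nM. These two values lie within the usual scatter of each other, so compound 2 cannot be separated from compound 1 on these numbers.

Compound 3 `CC(=O)Oc1ccc2c(c1)C(=O)C=CC2=O` has acetyl in place of allyl on an oxygen on an aromatic ring, compared with compound 2 (acetyl in place of allyl on an oxygen on an aromatic ring). Within the data shown here, no measured pair of compounds shows what a single change of this kind does in this assay, so any expectation is loose. The expected 1.5-fold lower number from compound 2 to compound 3 (0.16 log units; within the scatter) is small, towards a slightly lower number, and hardly beyond the scatter. For compound 3 the estimated value is 7000 nM, with an expected range of 2500 nM to 20000 nM.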

Compound 3, half-maximal inhibitory concentration: 22100 nM
Compound 3: middle estimate off by 3.2-fold (0.50 log units), on the low side; the measured number lies above the stated range.
By their numbers in this assay, from the lowest: compounds 2, 1 and 3 (each within the scatter of the next, the first and the last beyond it).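

In this assay, putting acetyl in place of allyl on an oxygen on an aromatic ring gives a 2.2-fold higher number from compound 2 to compound 3 (0.34 log units; beyond the scatter). Among these compounds, this is the first single change that can be read here, and it shows that the group on this oxygen can alter the number, though only modestly and towards weaker inhibition. No measurement at hand explains the step from allyloxy to acetoxy. Still open, as far as these compounds go, is how a longer chain or an amine-bearing group on this oxygen would compare, and whether a free hydroxyl there would give a higher or lower number.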